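Demethylation step in a cytotoxicity series

The compounds below may be only part of what the source reports. "The series", "measured", "known", "first", "only" and "open" are said of these compounds alone.

Of the compounds shown here, two have been measured so far. In a functional assay on CAKI-1 cells (Homo sapiens) for cytotoxicity, read by sulforhodamine B assay, with a stated time of 48 h, tested at 1 uM (on this read-out lower numbers stand for a stronger effect and higher numbers for a weaker effect at the one concentration tested), compound 1 `Cc1cc(O)cc(-c2nn(CC#N)cc2-c2ccnc(-c3ccc(Oc4ccccc4)cc3)c2)c1` gives -24%. In this assay compound 2 `COc1cc(C)cc(-c2nn(CC#N)cc2-c2ccnc(-c3ccc(N(C)C)cc3)c2)c1` gives 4%, the highest of the two numbers and beyond the scatter from compound 1. Compound 3 `Cc1cc(O)cc(-c2nn(CC#N)cc2-c2ccnc(-c3ccc(N(C)C)cc3)c2)c1` is the next member and is not yet measured. From compound 2 to compound 3 the change is hydrogen in place of methyl on an oxygen on an aromatic ring. Among the compounds with values here, no pair of measured compounds differs at this place alone, so the size of such a step in this assay has not been seen; compound 1 carries the hydroxy of compound 3 but differs elsewhere as well, so its value shows only what that whole compound does. A step of moderate size towards lower numbers is expected, with a range wide enough to include no change beyond the scatter. For compound 3 the expected value in this assay is -8%, between -38% and 18%. The expected step of a number 12 percentage points lower from compound 2 to compound 3 (beyond the scatter) is thus towards a stronger effect.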

Compound 3, a percentage reported as activity, at one concentration (the size of the read-out at that concentration, not a potency): 9%
The estimate for compound 3 lay 17 percentage points below the measured number; measured number inside the range.
By their numbers in this assay, from the lowest: compound 1; then compounds 2 and 3 (each within the scatter of the next).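

With the dimethylamino group held constant, the change from methoxy to hydroxy on an oxygen on an aromatic ring is now seen alone in this assay and gives a number 5 percentage points higher from compound 2 to compound 3 (within the scatter), so this position shows no response to this change beyond the scatter. The other place carries the larger difference: dimethylamino in place of phenoxy on an aromatic carbon gives a number 33 percentage points higher from compound 1 to compound 3 (beyond the scatter), and since both compounds carry the hydroxy, the low number of compound 1 goes with phenoxy and not with the hydroxy. Nothing at hand gives a reason for either step.

On these data alone, whether the methoxy to hydroxy step stays this small with phenoxy in the other place remains open. Also open, as far as these compounds go, is how an ethoxy group or an amino group would read on this position.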